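This account rests on a few compounds, and the source may have more. Where it says the series, first, only, none or still open, it means among the compounds named here.

Measured so far in a functional assay on HepG2 cells (Homo sapiens) for antiproliferative activity, read by MTT assay, with a stated time of 72 h; on this read-out higher numbers stand for weaker inhibition and lower numbers for stronger inhibition:
- Compound 1 `O=C1COc2ccc(-c3cnc(Cl)c(NS(=O)(=O)c4ccc(F)cc4)c3)cc2N1`: > 40000 nM (a limit of the assay)
- Compound 2 `COc1cccc(N2C(=O)COc3ccc(-c4cccc(NS(=O)(=O)c5ccc(F)cc5)c4)cc32)c1`: > 40000 nM (a limit of the assay)

Compound 2 has no exact number, only a limit. The two compounds share one reading, (the limit of > 40000 nM in this assay, at which 2 of the 2 values shown sit). Compound 3 `COc1ccc(N2C(=O)COc3ccc(-c4cccc(NS(=O)(=O)c5ccc(F)cc5)c4)cc32)cc1` has the same atoms as compound 2, joined differently: 4-methoxyphenyl in place of 3-methoxyphenyl on an amide-type nitrogen in a ring, with 4-methoxyphenyl in place of 3-methoxyphenyl on an amide-type nitrogen in a ring. For the measured compounds named here, no measured step guides this change, so no shift beyond the scatter is expected in this assay. The expected step of a number no higher from compound 2 to compound 3 (the limit leaves the size open) rests on compound 2, whose limit is > 40000 nM. For compound 3 the estimated value is 40000 nM, with an expected range from 15000 nM to 80000 nM.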

Compound 3, half-maximal inhibitory concentration: 29800 nM
The estimate for compound 3 lay 1.3-fold (0.13 log units) above the measured number; the range from low to high includes it.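

For the compounds shown here, the change to 4-methoxyphenyl in place of 3-methoxyphenyl on the amide-type nitrogen gives an at least 1.3-fold lower number from compound 2 to compound 3 (0.12 log units; that floor lies within the scatter) in this assay and provides the first exact number in this set. It shows that this nitrogen can carry a group while the read-out stays within the measurable range. From the compounds shown here alone, the true size of the step stays open because compound 2 has only a limit: the limit of > 40000 nM in this assay, at which 2 of the 3 values shown sit.

Going by these compounds, whether an amine or a carboxylic acid in place of the methoxy group would move the number further remains open. So does whether a shorter or longer chain on that oxygen would matter.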